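The source may hold more compounds than are shown below. What is called first, only, known or untested is meant among the compounds shown, and "the series" means these compounds.

Within the data shown here, the three compounds measured so far share one core carrying an ether-linked amide. Compound 1 `Cc1cc(C)cc(NC(=O)COc2cc(C)nc3ccc(OCc4ccccc4)cc23)c1` sits at the limit of a toxicity assay on HepG2 cells (Homo sapiens) for inhibition, read by CellTiter-Glo, with a stated time of 48 h (on this read-out higher numbers stand for weaker inhibition and lower numbers for stronger inhibition), where it gives > 100000 nM, a limit rather than a number. Compound 2 `CCC(Oc1cc(C)nc2ccc(OC)cc12)C(=O)Nc1cc(C)cc(C)c1` gives 79400 nM in this assay. Compound 3 `COc1ccc2nc(C)cc(OCC(=O)Nc3cc(C)ccc3C)c2c1` likewise reaches only the limit > 100000 nM in this assay. Where compound 3 stands among the numbers shown is therefore only a limit, and one further value is likewise a limit, as the limit of > 100000 nM in this assay, at which 2 of the 3 values shown sit, records. Among the measured compounds shown here, no step between two measured compounds that differ in one place is available. Compound 4 `COc1ccc2nc(C)cc(OCC(=O)Nc3ccc(Cl)c(OC)c3)c2c1` differs from compound 3 by 4-chloro-3-methoxyphenyl in place of 2,5-dimethylphenyl on an amide-type nitrogen. With nothing measured on this change, no direction is indicated; the step is expected to be a number no higher from compound 3 to compound 4 (the limit leaves the size open) and not to go beyond the usual scatter. Compound 4 is therefore estimated at 100000 nM, with a range from 40000 nM to 300000 nM in this assay, most probably reported again as a limit.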

Compound 4, half-maximal inhibitory concentration: > 100000 nM
Compound 4: no number, only a limit; the forecaster's own chance of this, stated with the estimate: 65%; the middle value sits exactly at the limit.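

Compound 3 and compound 4 both end at a limit rather than a number, so no step can be read between them: the limit of > 100000 nM in this assay, at which 3 of the 4 values shown sit.

The compounds shown leave open whether 4-chloro-3-methoxyphenyl in place of 2,5-dimethylphenyl on an amide-type nitrogen changes the read-out in this assay at all.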